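Butoxy for benzyl on the anilide ring

This account rests on a few compounds, and the source may have more. Where it says the series, first, only, none or still open, it means among the compounds named here.

Measured compounds:
- Compound 1, `Nc1nn(C(=O)Nc2ccc(Cc3ccccc3)cc2)c2ccccc12`: 21100 nM
- Compound 2, `COc1ccc(NC(=O)Nc2n[nH]c3ccccc23)cc1`: > 100000 nM

Of the compounds shown here, two have been measured in a functional assay on CAKI-1 cells (Homo sapiens) for inhibition, read by sulforhodamine B assay, with a stated time of 48 h; on this read-out higher numbers stand for weaker inhibition of growth and lower numbers for stronger inhibition of growth. Among the measured compounds shown here, compound 1 gives 21100 nM, the only plain number among the two values. Compound 2 reaches only a limit of the assay, at > 100000 nM, so no number is known for it; this is the limit of > 100000 nM in this assay, at which 1 of the 2 values shown sits. For the measured compounds named here, compound 1 therefore stands alone as the single measured value from which any expectation can be drawn.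

Compound 3, `CCCCOc1ccc(NC(=O)n2nc(N)c3ccccc32)cc1`, has not yet been measured. It differs from compound 1 in one place: butoxy in place of benzyl on an aromatic carbon, sitting para to a large group on that ring. Going by the values given here, no step between measured compounds with a single change is available, so the size of this step cannot be read from the data. The author expects a step in this assay of about a 1.4-fold higher number from compound 1 to compound 3 (0.15 log units; within the scatter) from compound 1 to compound 3, that is, no change beyond the usual scatter, with a slight lean toward weaker inhibition. Compound 3 is accordingly estimated at 30000 nM, within the range 8000 nM to 100000 nM.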

Compound 3, concentration for 50% growth inhibition: 28300 nM
Beside the measured number, compound 3's estimate is 1.1-fold (0.03 log units) above it; measured number inside the range.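

In this assay, butoxy in place of benzyl on an aromatic carbon, para to a large group, gives a 1.3-fold higher number from compound 1 to compound 3 (0.13 log units; within the scatter). Among the compounds shown here, this is the first single change that can be read, and it shows that this place on the anilide ring accepts an open chain with one oxygen in place of a six-membered aromatic ring of carbon only, with no difference beyond the scatter. The two groups differ in ring, heavy atoms and hydrogen-bond acceptors, yet the read-out does not separate them, and no measurement shown here bears on why that is so.

The compounds shown leave open whether a longer chain, an amine or a carboxylic acid at this same place would also stay within the scatter of compound 1, or whether one of them would move the read-out clearly in either direction. They also leave open whether butoxy and benzyl would remain this close on a core other than that of compound 1, or with a different group on the shared core.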